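This account rests on a few compounds, and the source may have more. Where it says the series, first, only, none or still open, it means among the compounds named here.

Compound 1 `O=C(/N=C/c1ccc([N+](=O)[O-])cc1)Nc1ccc2c(c1)C(=O)C(=O)N2CN1CCCCC1` and compound 2 `O=C(/N=C/c1cccc([N+](=O)[O-])c1)Nc1ccc2c(c1)C(=O)C(=O)N2CN1CCCCC1` share one core and differ only at the carbon with a double bond to nitrogen. In a functional assay on the whole organism (strain Swiss albino) with Mus musculus as the target, with a stated time of 4 h (a higher number here means that more compound is needed for the effect, a lower number that less compound is needed), compound 1 gives 300 mg/kg, and in this assay compound 2 gives 300 mg/kg; the step of no change at the digits printed from compound 1 to compound 2 (within the scatter) is the only one measured, so compound 2 stands level with compound 1. Compound 3 `O=C(/N=C/c1ccc(Br)cc1)Nc1ccc2c(c1)C(=O)C(=O)N2CN1CCCCC1` carries 4-bromophenyl in place of 3-nitrophenyl on a carbon with a double bond to nitrogen. For the measured compounds named here, no measured step covers a bromophenyl, and the one known step was flat, so for compound 3 the expected step of no change at the digits printed from compound 2 to compound 3 (within the scatter) is none beyond the scatter. Compound 3 is therefore estimated at 300 mg/kg, between 100 mg/kg and 600 mg/kg.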

Compound 3, minimum effective dose: 300 mg/kg
The estimate for compound 3 equals the measured number at the digits printed; measured number inside the range.
By their numbers in this assay, from the lowest: compounds 1, 2 and 3 (each within the scatter of the next).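

In this assay the step of no change at the digits printed from compound 2 to compound 3 (within the scatter) shows that this carbon with a double bond to nitrogen can carry a 4-bromophenyl as readily as a 3-nitrophenyl, so the nitro group is not needed to keep this value. The step of no change at the digits printed from compound 1 to compound 3 (within the scatter) confirms this for bromo in place of nitro on an aromatic carbon. Nothing available explains why these changes leave the dose unmoved. Still open, going by these compounds, is whether an amine or a carboxylic acid on this phenyl ring, or a longer chain in its place, would shift the minimum effective dose in either direction.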